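Triazole for imidazole on the benzyl arene of the core

The compounds below may be only part of what the source reports. "The series", "measured", "known", "first", "only" and "open" are said of these compounds alone.

Compound 1 `Cc1cc(C)c(NC(=O)N(Cc2ccc(-c3ccccn3)cc2)C2CCCCCC2)c(C)c1` carries a pyridin-2-yl group on the benzyl arene of the shared core. In a functional assay on a cell-free system (plasma) with sterol O-acyltransferase, Soat (Rattus norvegicus) as the target (on this read-out lower numbers stand for an effect already at smaller amounts and higher numbers for an effect only at larger amounts of compound), compound 1 gives > 1 mg/kg, which is a limit of the assay and not a number. Compound 2 `Cc1cc(C)c(NC(=O)N(Cc2ccc(-c3cc[nH]n3)cc2)C2CCCCCC2)c(C)c1` carries 1H-pyrazol-3-yl in its place. In this assay compound 2 gives > 1 mg/kg, again a limit. Compound 3 `Cc1cc(C)c(NC(=O)N(Cc2ccc(-n3ccnc3)cc2)C2CCCCCC2)c(C)c1` carries 1H-imidazol-1-yl. In this assay compound 3 gives > 1 mg/kg, also a limit. The steps a step that the two limits leave unreadable from compound 1 to compound 2, a step that the two limits leave unreadable from compound 1 to compound 3 and a step that the two limits leave unreadable from compound 2 to compound 3 are therefore of unreadable size; all that is known is the limit of > 1 mg/kg in this assay, at which 3 of the 3 values shown sit. Compound 3 thus stands at that limit alongside both other measured compounds, with no number that would set it apart from them.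

Compound 4 `Cc1cc(C)c(NC(=O)N(Cc2ccc(-n3ccnn3)cc2)C2CCCCCC2)c(C)c1` differs from compound 3 by 1H-1,2,3-triazol-1-yl in place of 1H-imidazol-1-yl on an aromatic carbon. Going by the values given here, no measured step reads on a change of this kind, since every step among compounds 1, 2 and 3 is hidden by the limits. Given (the limit of > 1 mg/kg in this assay, at which 3 of the 3 values shown sit), compound 4 is expected to behave like compound 3, and the estimated step that the limit leaves unreadable from compound 3 to compound 4 is none beyond the scatter. Compound 4 is estimated at 3 mg/kg in this assay, with a range from 1 mg/kg to 15 mg/kg, and this assay will most likely report only a limit again.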

Compound 4, dose for half-maximal effect: > 1 mg/kg
Compound 4: only a limit was reported; the forecaster's own chance of this, stated with the estimate: 80%; the middle value lies beyond the limit too.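

In this assay compound 4 gives > 1 mg/kg, which is a limit and not a number. Its steps from compound 1, compound 2 and compound 3 cannot be read, so no new step follows: the limit of > 1 mg/kg in this assay, at which 4 of the 4 values shown sit.

The compounds shown leave open how pyridin-2-yl, 1H-pyrazol-3-yl, 1H-imidazol-1-yl and 1H-1,2,3-triazol-1-yl compare in this assay.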